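Aryloxypropoxy triazine series: halogen swap on the phenyl ring

The source may report more compounds than this note shows. Statements on the series, on what has been measured and on what is new or still open speak of the compounds shown alone.

Measured so far:
compound 1 `NC1=NC2(CCOCC2)N(OCCCOc2ccc(Cl)c(Cl)c2)C(N)=N1` — 380 nM
compound 2 `NC1=NC2(CCSCC2)N(OCCCOc2ccc(Cl)cc2)C(N)=N1` — 1100 nM

In a functional assay on HepG2 cells (Homo sapiens) for antiproliferative activity, read by MTT assay, with a stated time of 72 h (on this read-out lower numbers stand for stronger inhibition and higher numbers for weaker inhibition), compound 2 gives 1100 nM, the higher of the two numbers recorded; compound 1 gives 380 nM, and the gap lies beyond the scatter. Compound 3 `NC1=NC2(CCSCC2)N(OCCCOc2ccccc2Br)C(N)=N1` is not yet measured. It differs from compound 2 by 2-bromophenyl in place of 4-chlorophenyl on an oxygen on a saturated carbon. Among the measured compounds shown here, no measured pair isolates this change, so the direction is open; a step of modest size, perhaps none beyond the scatter, is expected. The estimate for compound 3 is 1300 nM (range 450 nM to 3800 nM), a step of a 1.2-fold higher number from compound 2 to compound 3 (0.07 log units; within the scatter).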

Compound 3, half-maximal inhibitory concentration: 90 nM
The estimate for compound 3 lay 14-fold (1.16 log units) above the measured number; measured number outside the range, below it.
By their numbers in this assay, from the lowest: compound 3; then compound 1; then compound 2.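

The aryl group on an oxygen on a saturated carbon is a sensitive place in the series: in this assay, 2-bromophenyl in place of 4-chlorophenyl gives a 12-fold lower number from compound 2 to compound 3 (1.09 log units; beyond the scatter), although the heavy-atom count stays the same. The change swaps the halogen and moves it on the ring in one step, so the two cannot be separated here. No measurement at hand accounts for the size of this step.

On these data alone, whether the bromine or its place on the ring carries the step stays open. As far as these compounds go, how an amine or a carboxylic acid in place of the bromine would read also stays open.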